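Working notes: from compound 3 to compound 4

The compounds below may be only part of what the source reports. "The series", "measured", "known", "first", "only" and "open" are said of these compounds alone.

Measured in a functional assay on a cell-free system (plasma, Oryctolagus cuniculus) for inhibition, with stated times of 5 min, 1 min and 6 min; a lower number here means a stronger inhibitor, a higher number a weaker inhibitor:
- compound 1 `CCOC(=O)c1c(C)nc(-c2cccc(C#N)c2)n1OC`: 9130 nM
- compound 2 `CCOC(=O)c1c(C)nc(-c2cccc(C#N)c2)n1OCc1ccc(C)cc1`: 6310 nM
- compound 3 `CCOC(=O)c1c(C)nc(-c2cccc(C#N)c2)n1OCc1ccc(C(=O)OC)cc1`: 9470 nM

Compound 3, at 9470 nM, lies within the scatter of both compound 1 and compound 2. The next structure is compound 4 `CCOC(=O)c1c(C)nc(-c2cccc(C#N)c2)n1OCc1cccc(C#N)c1`, and the change is 3-cyanophenyl in place of 4-(methoxycarbonyl)phenyl on a saturated chain carbon bound to an oxygen on an aromatic ring. This places 3-cyanophenyl in place of 4-(methoxycarbonyl)phenyl on a saturated chain carbon bound to an oxygen on an aromatic ring.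

Among the measured compounds shown here, three measured steps bear on this: a 1.4-fold lower number from compound 1 to compound 2 (0.16 log units; within the scatter), a 1.0-fold higher number from compound 1 to compound 3 (0.02 log units; within the scatter) and a 1.5-fold higher number from compound 2 to compound 3 (0.18 log units; within the scatter). All stay within the scatter, so no step beyond it is expected in this assay. The expected step is a 1.2-fold lower number from compound 3 to compound 4 (0.07 log units; within the scatter). Compound 4 is estimated at 8000 nM, with an expected range of 4000 nM to 15000 nM.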

Compound 4, half-maximal inhibitory concentration: > 30000 nM
Compound 4: no number, only a limit; the forecaster's own chance of this, stated with the estimate: 5%; middle value at least 3.7-fold (0.57 log units) away from the limit.
By their numbers in this assay, from the lowest: compounds 2, 1 and 3 (each within the scatter of the next). At a limit, above all of these: compound 4.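

In this assay, compound 4 gives a limit and not a number: the limit of > 30000 nM in this assay, at which 1 of the 4 values shown sits. The group on the saturated chain carbon bound to an oxygen on an aromatic ring can therefore matter: 3-cyanophenyl gives an at least 3.1-fold higher number from compound 3 to compound 4 (0.50 log units; beyond the scatter), an at least 4.7-fold higher number from compound 2 to compound 4 (0.67 log units; beyond the scatter) and an at least 3.2-fold higher number from compound 1 to compound 4 (0.51 log units; beyond the scatter), whereas hydrogen, 4-methylphenyl and 4-(methoxycarbonyl)phenyl stay within the scatter of one another.

Going by these compounds, it remains open whether this step follows the nitrile itself or its place on the phenyl ring, as 4-cyanophenyl would test. Also open, on these data alone, is how a phenyl ring bearing an amine or a carboxylic acid would behave here.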